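Methylating the phenol: from compound 2 to compound 4

The source may report more compounds than this note shows. Statements on the series, on what has been measured and on what is new or still open speak of the compounds shown alone.

Measured compounds:
compound 1, `Cc1cc(NC(=O)c2cc([N+](=O)[O-])ccc2Cl)cc(-c2nc3ccccc3s2)c1O`: 48 10^-6 cm/s
compound 2, `O=C(Nc1ccc(O)c(-c2nc3ccccc3s2)c1)c1cc([N+](=O)[O-])ccc1Cl`: "below limit of detection" (no number reported)
compound 3, `O=C(Nc1cc(-c2nc3ccccc3o2)ccc1F)c1cc([N+](=O)[O-])ccc1Cl`: 214 10^-6 cm/s

In an ADME assay for permeability, using PAMPA, at pH 7.4 (on this read-out lower numbers stand for lower permeability and higher numbers for higher permeability), compound 1 gives 48 10^-6 cm/s and compound 3 gives 214 10^-6 cm/s. Compound 2 has no number in this assay; its result there is recorded as "below limit of detection" (no number reported), so no figure is available for comparison. Compound 2 therefore stands apart from the other two, which both return readable numbers, and no step between any pair of these compounds is available.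

Compound 4, `COc1ccc(NC(=O)c2cc([N+](=O)[O-])ccc2Cl)cc1-c1nc2ccccc2s1`, differs from compound 2 in one place: methyl in place of hydrogen on an oxygen on an aromatic ring. Cut one bond further out, the same change reads hydroxy to methoxy. Among the compounds with values here, since compound 2 returned no number in this assay, no step can be quoted; the expectation is that compound 4 moves upward into the readable range, by a margin beyond the scatter, toward where compound 1 sits. The permeability of compound 4 in this assay is estimated at 80 10^-6 cm/s, with a range from 20 10^-6 cm/s to 250 10^-6 cm/s.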

Compound 4, apparent permeability in the ADME assay: "below limit of detection" (no number reported)
For compound 4 the study gives words and no number, and the estimate cannot be compared.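

Within the data shown here, compound 2 and compound 4 both return words and no number in the ADME assay, so no step between them can be read there. In a physicochemical assay for solubility, read by spectrophotometry, in phosphate buffer, measured as kinetic solubility, with a stated time of 18 h, at pH 7.4 (on this read-out lower numbers stand for lower solubility and higher numbers for higher solubility), compound 2 gives 23 nM and compound 4 gives 260 nM. The compounds shown leave open how the permeability of compound 4 compares with that of compound 2.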